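The compounds below may be only part of what the source reports. "The series", "measured", "known", "first", "only" and "open" are said of these compounds alone.

In a functional assay on NCI-H460 cells (Homo sapiens) for inhibition, with a stated time of 72 h (on this read-out higher numbers stand for weaker inhibition and lower numbers for stronger inhibition), three compounds have been measured:

Compound 1 `COc1ccc(S(=O)(=O)N2CCc3cccc(-c4cccnc4)c32)cc1`: 89.6 nM
Compound 2 `COc1ccc(S(=O)(=O)N2CCc3cccc(-c4ccc(C#N)cc4)c32)cc1`: 29.5 nM
Compound 3 `COc1ccc(-c2cccc3c2N(S(=O)(=O)c2ccc(OC)cc2)CC3)cc1`: 302 nM

Compound 1 stands second highest of the three numbers; compound 2 sits a 3.0-fold lower number from compound 1 to compound 2 (0.48 log units; beyond the scatter), and compound 3 sits a 3.4-fold higher number from compound 1 to compound 3 (0.53 log units; beyond the scatter). Compound 4 `COc1ccc(S(=O)(=O)N2CCc3cccc(-c4cccs4)c32)cc1` has not yet been measured. It differs from compound 1 in one place: thiophen-2-yl in place of pyridin-3-yl on an aromatic carbon. Both measured steps from compound 1 replace the pyridin-3-yl with another aromatic group, and both were modest, one in each direction. Thiophen-2-yl carries neither the cyano of compound 2 nor the methoxy of compound 3, so a step of at most modest size in either direction is expected in this assay, with a 1.3-fold lower number from compound 1 to compound 4 (0.11 log units; within the scatter) as the central guess. Compound 4 is therefore estimated at 70 nM, within 25 nM to 200 nM.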

Compound 4, half-maximal inhibitory concentration: 229 nM
Compound 4: middle estimate off by 3.3-fold (0.51 log units), on the low side; the whole stated range lies below it.
By their numbers in this assay, from the lowest: compound 2; then compound 1; then compounds 4 and 3 (each within the scatter of the next).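

In this assay thiophen-2-yl in place of pyridin-3-yl gives a 2.6-fold higher number from compound 1 to compound 4 (0.41 log units; beyond the scatter) and so does not match the six-membered ring it replaces. Thiophen-2-yl in place of 4-methoxyphenyl gives a 1.3-fold lower number from compound 3 to compound 4 (0.12 log units; within the scatter) and these two groups cannot be told apart here, while thiophen-2-yl in place of 4-cyanophenyl gives a 7.8-fold higher number from compound 2 to compound 4 (0.89 log units; beyond the scatter) and leaves 4-cyanophenyl the only one of the four groups with a lower number than pyridin-3-yl. Nothing at hand explains these differences.

Going by these compounds, what an amine or a carboxylic acid in place of the cyano of compound 2 would give stays open, as does whether furan-2-yl would behave like thiophen-2-yl.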